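The source may report more compounds than this note shows. Statements on the series, on what has been measured and on what is new or still open speak of the compounds shown alone.

Measured so far:
- compound 1 `Cc1ncc(CO)c2c(Nc3ccccn3)c(N)oc12`: "not active" (no number reported)
- compound 2 `Cc1ncc(CO)c2c(Nc3ccccn3)c(NC3CCCCC3)oc12`: 6930 nM
- compound 3 `Cc1ncc(CO)c2c(Nc3ccccn3)c(NC(C)(C)CC(C)(C)C)oc12`: "not active" (no number reported)

All three compounds share the same core and were tested in a functional assay on HEK293 cells for agonist activity at Toll-like receptor 8 (Homo sapiens), read by reporter gene assay; a higher number here means that more compound is needed for the effect, a lower number that less compound is needed. Compound 1 stands at the bottom of what can be said: in this assay compound 1 is recorded as "not active" (no number reported), so no number is known for it. Compound 3 also gives "not active" (no number reported) in this assay and is in the same position. Only compound 2 yields a number, giving 6930 nM in this assay, and that number is itself high, meaning a large amount of compound is needed.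

Compound 4 `Cc1ncc(CO)c2c(Nc3ccccn3)c(NCCC(=O)OC(C)(C)C)oc12` is the next step from compound 1. The change is 2-(tert-butoxycarbonyl)ethyl in place of hydrogen on a nitrogen on an aromatic ring. Within the data shown here, since compound 1 reports no number, no step in this assay can be computed for this pair, and the expected size of the step rests on compound 2 alone: a group placed on that nitrogen can turn an inactive compound into one with a measurable, if weak, value, while compound 3 shows that this does not always happen. The expectation for compound 4 is therefore a weak but measurable response, with a real chance of no number at all. Compound 4 is estimated to give 10000 nM in this assay, within a range from 3000 nM to 40000 nM.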

Compound 4, half-maximal effective concentration: 7640 nM
Compound 4: the middle estimate sits 1.3-fold (0.12 log units) above what was measured, within the range that was stated.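

With compound 4, a second group on this nitrogen on an aromatic ring gives a number in this assay, whereas compound 1, with hydrogen there, gives none, so the step between them cannot be read; compound 3 goes against this pattern, as its group also leaves no number. Cyclohexyl and 2-(tert-butoxycarbonyl)ethyl, which has no ring, give values that cannot be told apart (a 1.1-fold higher number from compound 2 to compound 4 (0.04 log units; within the scatter)), so among these compounds a ring on this nitrogen is not required for a measurable response. Nothing available here explains why compounds 2 and 4 give a number while compound 3 does not.

From the compounds shown here alone, it remains open whether a free carboxylic acid in place of the tert-butyl ester, a terminal amine, or a longer unbranched carbon chain would keep a measurable response at this position. Going by these compounds, it is also open whether any group on this nitrogen can bring the number well down from where compound 2 and compound 4 stand, since these two alone offer no such direction.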